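One Chlorine Atom Added to Compound 3

The compounds below may be only part of what the source reports. "The series", "measured", "known", "first", "only" and "open" are said of these compounds alone.

Compound 1, `CN(Cc1ccc2nccn2c1)c1nnc(-c2ccccc2)o1`: 2.4
Compound 2, `Cc1ccccc1-c1ccc(-c2nnc(N(C)Cc3ccc4nccn4c3)o2)cc1`: 4.7
Compound 3, `Cc1nn(C)c(C)c1-c1ccc(-c2nnc(N(C)Cc3ccc4nccn4c3)o2)cc1`: 3.1

Of the compounds shown here, three share one core and have been measured in a physicochemical assay for lipophilicity, at pH 7.4; a lower number here means a more polar compound, a higher number a more lipophilic compound. Compound 1 carries hydrogen at the position in question and gives 2.4. Compound 2 carries a 2-methylphenyl group there and gives 4.7, a step of a number 2.30 log units higher from compound 1 to compound 2 (beyond the scatter). Compound 3 carries a 1,3,5-trimethyl-1H-pyrazol-4-yl group and gives 3.1, which places it second highest of the three: it lies above compound 1 by a number 0.70 log units higher from compound 1 to compound 3 (beyond the scatter) and below compound 2 by a number 1.60 log units lower from compound 2 to compound 3 (beyond the scatter).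

Compound 4, `Cc1nn(C)c(C)c1-c1ccc(-c2nnc(N(C)Cc3ccc4nccn4c3)o2)c(Cl)c1`, differs from compound 3 in one place: chloro in place of hydrogen on an aromatic carbon. For the measured compounds named here, none of the three measured steps exchanges hydrogen for chlorine, so no direct precedent exists in this set. All three steps do show that adding atoms to this aromatic ring raised the number in this assay, and a single chlorine is a much smaller addition than either ring group. A modest upward step is therefore expected, and the estimate for compound 4 is 3.7, within 3.3 to 4.1, corresponding to an expected step of a number 0.60 log units higher from compound 3 to compound 4 (beyond the scatter).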

Compound 4, distribution coefficient: 3.3
Beside the measured number, compound 4's estimate is 0.40 log units above it, and the stated range covers the measured number.
By their numbers in this assay, from the lowest: compound 1; then compounds 3 and 4 (each within the scatter of the next); then compound 2.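

In this assay chloro on this aromatic carbon, ortho to a large group and meta to the 1,3,5-trimethyl-1H-pyrazol-4-yl group, gives a number 0.20 log units higher from compound 3 to compound 4 (within the scatter) and so compound 3 and compound 4 cannot be told apart in this measurement. For the compounds shown here, every earlier step exchanged a whole ring group and lay beyond the scatter, even the smallest of them, which is a number 0.70 log units higher from compound 1 to compound 3 (beyond the scatter) and still a clear move, so this single chlorine atom is the first exchange in the set that leaves the number inside the scatter. Nothing available here explains why the number stays so close at this position.

The compounds shown leave open whether a larger or differently built group on the same carbon, such as an amine, a carboxylic acid or a longer chain, would move the number beyond the scatter. Going by these compounds alone, they also leave open whether chloro would give a similarly small step on the core of compound 1 or alongside the 2-methylphenyl group of compound 2, since this one exchange is seen only with the 1,3,5-trimethyl-1H-pyrazol-4-yl group in place.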